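The source may hold more compounds than are shown below. What is called first, only, known or untested is meant among the compounds shown, and "the series" means these compounds.

The measured compounds are:

- compound 1, `O=c1cc(-n2cc(-c3ccccc3)nn2)c2cc(Br)ccc2o1`, which in a functional assay on A549 cells (Homo sapiens) for antiproliferative activity, read by MTT assay, with a stated time of 48 h (a higher number here means a weaker inhibitor, a lower number a stronger inhibitor), gives 11200 nM
- compound 2, `O=c1cc(-n2cc(CNc3ccccc3)nn2)c2cc(Br)ccc2o1`, which in this assay gives 13200 nM
- compound 3, `CCc1ccc(OCc2cn(-c3cc(=O)oc4ccc(Br)cc34)nn2)cc1`, which in this assay gives 11600 nM

Compound 3 stands second highest of the three values; its nearest neighbour is compound 1 and its furthest is compound 2, and both of those gaps lie within the scatter, so the three compounds cannot be told apart on these numbers.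

Compound 4, `O=c1cc(-n2cc(COc3ccc(F)cc3)nn2)c2cc(Br)ccc2o1`, differs from compound 3 in one place: fluoro in place of ethyl on an aromatic carbon.

Two steps are known, a 1.2-fold higher number from compound 1 to compound 2 (0.07 log units; within the scatter) and a 1.1-fold lower number from compound 2 to compound 3 (0.06 log units; within the scatter). Both change the group carried on the shared core, and neither moved the number beyond the scatter. Within the data shown here, neither of them touches a substituent on the outer six-membered aromatic ring of carbon only, so there is no measured step of the same kind as the change from compound 3 to compound 4. With the whole set sitting in one narrow band, the expectation is a step of no change at the digits printed from compound 3 to compound 4 (within the scatter) in this assay, that is, none beyond the scatter.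

Compound 4 is therefore estimated at 11600 nM in this assay, with a range from 5800 nM to 23000 nM.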

Compound 4, half-maximal inhibitory concentration: 850 nM
Compound 4: middle estimate off by 14-fold (1.14 log units), on the high side; the whole stated range lies above it.
By their numbers in this assay, from the lowest: compound 4; then compounds 1, 3 and 2 (each within the scatter of the next).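

In this assay, among these compounds, the substituent on the outer ring matters far more than the earlier compounds suggested: fluoro in place of ethyl, on an aromatic carbon of a six-membered aromatic ring of carbon only and para to a large group, gives a 14-fold lower number from compound 3 to compound 4 (1.14 log units; beyond the scatter), whereas the earlier changes to the group carried on the shared core stayed within the scatter. The same contrast appears when anilino is replaced: 4-fluorophenoxy gives a 16-fold lower number from compound 2 to compound 4 (1.19 log units; beyond the scatter), while 4-ethylphenoxy gives only a 1.1-fold lower number from compound 2 to compound 3 (0.06 log units; within the scatter), so the effect of that exchange depends on the substituent the new group carries. No measurement shown here offers an explanation for the size of this step.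

As far as these compounds go, with only ethyl and fluoro compared at this place, it remains open whether an unsubstituted phenoxy, a chloro or a methoxy group would give a number close to that of compound 4 or close to that of compound 3, and so whether fluoro lowers the number or ethyl raises it. Also open, from the compounds shown here alone, is whether fluoro on the outer ring of compound 1 or compound 2 would produce a step of similar size.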